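Aryl change on the sulfonyl sulfur of compound 1

This account rests on a few compounds, and the source may have more. Where it says the series, first, only, none or still open, it means among the compounds named here.

All three measured compounds share one core and differ only in the aryl group on the sulfonyl sulfur. Going by the values given here, compound 1 `Cc1ccccc1C(=O)c1cnc(NCCCNS(=O)(=O)c2cccc(F)c2)s1` gives 5.5 nM in an assay on isolated protein for inhibition of Neuropeptide Y receptor type 5 (Mus musculus) (on this read-out higher numbers stand for weaker inhibition and lower numbers for stronger inhibition), the second highest of the three numbers so far. Compound 2 `COc1cccc(S(=O)(=O)NCCCNc2ncc(C(=O)c3ccccc3C)s2)c1` gives 11 nM in this assay, and compound 3 `COc1ccc(C)cc1S(=O)(=O)NCCCNc1ncc(C(=O)c2ccccc2C)s1` gives 0.71 nM. Of the steps among them, a 2.0-fold higher number from compound 1 to compound 2 (0.30 log units; within the scatter) stays within the scatter, whereas a 7.7-fold lower number from compound 1 to compound 3 (0.89 log units; beyond the scatter) and a 15-fold lower number from compound 2 to compound 3 (1.19 log units; beyond the scatter) both go beyond it.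

Compound 4 `Cc1ccccc1C(=O)c1cnc(NCCCNS(=O)(=O)c2cc(C(F)(F)F)ccc2Cl)s1` has not yet been measured in this assay. It differs from compound 1 in one place: 2-chloro-5-(trifluoromethyl)phenyl in place of 3-fluorophenyl on a sulfonyl sulfur. The step that bears most on this change is a 7.7-fold lower number from compound 1 to compound 3 (0.89 log units; beyond the scatter), where likewise a different aryl group entered in place of 3-fluorophenyl on the sulfonyl sulfur. The groups entering here are not the same, so a gain of that size is not assured; a step of modest size toward a lower number, or none beyond the scatter, is expected. Compound 4 is therefore estimated at 3 nM in this assay, with a range from 0.7 nM to 13 nM. The expected step is a 1.8-fold lower number from compound 1 to compound 4 (0.26 log units; within the scatter).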

Compound 4, half-maximal inhibitory concentration: 0.85 nM
Beside the measured number, compound 4's estimate is 3.5-fold (0.55 log units) above it, within the range that was stated.
By their numbers in this assay, from the lowest: compounds 3 and 4 (each within the scatter of the next); then compounds 1 and 2 (each within the scatter of the next).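

The step to the new aryl group is a 6.5-fold lower number from compound 1 to compound 4 (0.81 log units; beyond the scatter) in this assay, so the gain seen with 2-methoxy-5-methylphenyl is not unique to that group. The two aryl groups share no substituent, yet a 1.2-fold higher number from compound 3 to compound 4 (0.08 log units; within the scatter) leaves them indistinguishable in this read-out. With a 13-fold lower number from compound 2 to compound 4 (1.11 log units; beyond the scatter) as well, both aryl groups with two substituents give lower numbers than both with one among these four compounds, and none of the four goes against this.

Left open is how an amine or a carboxylic acid on the aryl group would read, and whether a longer chain on the sulfonamide nitrogen would keep these values. No measurement shown here accounts for these steps.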